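The source may report more compounds than this note shows. Statements on the series, on what has been measured and on what is new or still open speak of the compounds shown alone.

Three measured compounds share one core and differ only in the halogenated phenyl group on a saturated chain carbon bound to a nitrogen on an aromatic ring. In a functional assay on HL-60 cells (Homo sapiens) for antiproliferative activity, with a stated time of 72 h (on this read-out lower numbers stand for stronger inhibition and higher numbers for weaker inhibition), compound 1 `OC[C@H]1O[C@@H](n2cnc3c(NCc4ccccc4F)ncnc32)[C@H](O)[C@@H]1O` gives 3200 nM, compound 2 `OC[C@H]1O[C@@H](n2cnc3c(NCc4ccc(Cl)cc4)ncnc32)[C@H](O)[C@@H]1O` gives 1700 nM and compound 3 `OC[C@H]1O[C@@H](n2cnc3c(NCc4ccc(Cl)c(Cl)c4)ncnc32)[C@H](O)[C@@H]1O` gives 2000 nM. Compound 3 holds the middle of these three numbers, but no gap among them leaves the scatter of repeated measurements.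

The unmeasured compound 4 `OC[C@H]1O[C@@H](n2cnc3c(NCc4ccc(F)cc4F)ncnc32)[C@H](O)[C@@H]1O` differs from compound 3 by a single exchange: 2,4-difluorophenyl in place of 3,4-dichlorophenyl on a saturated chain carbon bound to a nitrogen on an aromatic ring. Here 2,4-difluorophenyl comes in place of 3,4-dichlorophenyl. Going by the values given here, no measured step makes this exact exchange, so the nearest evidence is indirect. There is a 1.6-fold lower number from compound 1 to compound 3 (0.20 log units; within the scatter), for 3,4-dichlorophenyl in place of 2-fluorophenyl. There is also a 1.9-fold lower number from compound 1 to compound 2 (0.27 log units; within the scatter), for 4-chlorophenyl in place of 2-fluorophenyl, and a 1.2-fold higher number from compound 2 to compound 3 (0.07 log units; within the scatter), for chloro in place of hydrogen. All three steps are small. The new group keeps the fluoro of compound 1 at 3200 nM, so a slight drift toward that number is possible, but no step beyond the scatter is expected in this assay. The expected change is a 1.3-fold higher number from compound 3 to compound 4 (0.10 log units; within the scatter). For compound 4 the estimate is 2500 nM, with an expected range from 1200 nM to 5000 nM.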

Compound 4, half-maximal inhibitory concentration: 3400 nM
Compound 4: the middle estimate sits 1.4-fold (0.13 log units) below what was measured; low and high end bracket the measured number.
By their numbers in this assay, from the lowest: compounds 2, 3, 1 and 4 (each within the scatter of the next).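

In this assay, 2,4-difluorophenyl in place of 3,4-dichlorophenyl on a saturated chain carbon bound to a nitrogen on an aromatic ring gives a 1.7-fold higher number from compound 3 to compound 4 (0.23 log units; within the scatter) and in place of 4-chlorophenyl it gives a 2.0-fold higher number from compound 2 to compound 4 (0.30 log units; within the scatter) so replacing chlorine-bearing rings with this fluorine-only ring leaves both steps within the scatter. The last new comparison gives a 1.1-fold higher number from compound 1 to compound 4 (0.03 log units; within the scatter) and this means that a second fluoro on the ring of compound 1 also makes no measurable difference, so all four halogen patterns now seen at this position remain within the scatter of their neighbours in this series. No measurement of any property of these groups comes with the numbers, so nothing explains even these small steps.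

On these data alone, all four groups are halogenated phenyl rings, so it remains open how this position would respond to a plain phenyl, a methoxy group, an amine or a carboxylic acid on the ring, or to a longer chain before it. Whether any exchange here can move the number beyond the scatter also remains unanswered.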